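The compounds below may be only part of what the source reports. "The series", "measured", "known", "first", "only" and "open" are said of these compounds alone.

In an ADME assay on MT4 cells (Homo sapiens) for cytotoxicity, read by MTT assay (on this read-out lower numbers stand for higher toxicity in this test and higher numbers for lower toxicity in this test), compound 1 (`Cc1ccccc1C(=O)N(C(=S)OCCN1C(=O)c2ccccc2C1=O)c1ccc(Cl)cc1`) gives 21000 nM, and compound 2 (`Cc1cccc(C(=O)N(C(=S)OCCN2C(=O)c3ccccc3C2=O)c2ccc(Cl)cc2)c1`) gives 58000 nM. Compound 3 (`O=C1c2ccccc2C(=O)N1CCOC(=S)N(C(=O)c1ccc([N+](=O)[O-])cc1)c1ccc(Cl)cc1`) gives only a limit of the assay, > 100000 nM. Compound 4 (`O=C1c2ccccc2C(=O)N1CCOC(=S)N(C(=O)c1cccc(F)c1F)c1ccc(Cl)cc1`) has 2,3-difluorophenyl in place of 4-nitrophenyl on a carbonyl carbon. Three measured changes at this same place bear on it: a 2.8-fold higher number from compound 1 to compound 2 (0.44 log units; beyond the scatter), an at least 4.7-fold higher number from compound 1 to compound 3 (0.67 log units; beyond the scatter) and an at least 1.7-fold higher number from compound 2 to compound 3 (0.23 log units; that floor lies within the scatter). These steps are modest or bounded only by a floor, and neither methylphenyl compound reaches the limit. A modest move to a lower number is therefore expected, an at least 2.0-fold lower number from compound 3 to compound 4 (0.30 log units; that floor lies within the scatter), although another limit remains possible. For compound 4 the estimated value is 50000 nM, with an expected range from 18000 nM to 100000 nM.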

Compound 4, half-maximal cytotoxic concentration: 58000 nM
Estimate against measurement, compound 4: 1.2-fold (0.06 log units) below; the measured number falls inside the stated range.
By their numbers in this assay, from the lowest: compound 1; then compounds 2 and 4 (each within the scatter of the next). At a limit, above all of these: compound 3.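

In this assay, 2,3-difluorophenyl on this carbonyl carbon gives no change at the digits printed from compound 2 to compound 4 (within the scatter), and it also gives a 2.8-fold higher number from compound 1 to compound 4 (0.44 log units; beyond the scatter). Among the compounds shown, a ring bearing fluorine thus matches 3-methylphenyl and stands apart from 2-methylphenyl. Compound 3 remains at a limit of the assay, leaving an at least 1.7-fold lower number from compound 3 to compound 4 (0.23 log units; that floor lies within the scatter) as only a floor: the limit of > 100000 nM in this assay, at which 1 of the 4 values shown sits.

Going by these compounds, how far compound 3 truly lies from compound 4 stays open. So does what an unsubstituted phenyl, a 4-fluorophenyl or a 4-aminophenyl group would give on this carbonyl carbon.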